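The source may hold more compounds than are shown below. What is called first, only, known or untested is meant among the compounds shown, and "the series" means these compounds.

Measured so far:
compound 1, `O=C(c1ccccc1)N1CCC(NCCSC(c2ccc(F)cc2)c2ccc(F)cc2)CC1`, 2.03 nM
compound 2, `O=C(c1ccccc1)N1CCC(NCC[S+]([O-])C(c2ccc(F)cc2)c2ccc(F)cc2)CC1`, 585 nM

Both compounds were tested in an assay on membranes from Cortex for displacement of a labelled ligand from Sigma non-opioid intracellular receptor 1 (Cavia porcellus), read by scintillation counting, with a stated time of 120 min; a higher number here means a weaker inhibitor, a lower number a stronger inhibitor. Going by the values given here, compound 1 gives 2.03 nM, the lowest of the two numbers, and compound 2 gives 585 nM, a gap that lies beyond the scatter of repeated measurements; no step between the two is set out here, so the account says only what the two values show.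

Compound 3, `O=C(c1ccc(F)cc1F)N1CCC(NCCSC(c2ccc(F)cc2)c2ccc(F)cc2)CC1`, has not yet been measured in this assay. It differs from compound 1 in one place: 2,4-difluorophenyl in place of phenyl on a carbonyl carbon. The shared core is otherwise kept, and the part that separates compound 1 from compound 2 is untouched.

Among the compounds with values here, with no measured step of this kind to lean on, the expectation for compound 3 in this assay rests on compound 1 alone, which gives 2.03 nM. The estimated step of a 1.5-fold higher number from compound 1 to compound 3 (0.17 log units; within the scatter) is expected to be small, with no clear direction and quite possibly none beyond the scatter. Compound 3 is therefore estimated at 3 nM, with a range from 0.8 nM to 12 nM.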

Compound 3, inhibition constant: 20.6 nM
Compound 3: the middle estimate sits 6.9-fold (0.84 log units) below what was measured; measured number outside the range, above it.
By their numbers in this assay, from the lowest: compound 1; then compound 3; then compound 2.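

In this assay, the change at this position gives a 10-fold higher number from compound 1 to compound 3 (1.01 log units; beyond the scatter), a step that comes from 2,4-difluorophenyl in place of phenyl on a carbonyl carbon while the rest of the shared core stays the same. Compound 1 and compound 2 both carry phenyl here, so they could say nothing about this part of the molecule; the new step shows that the number in this assay responds to a change in the group on the carbonyl carbon, and that this response is large. No measurement given here bears on why adding the two fluorines has this result.

The compounds shown leave open whether both fluorines are needed for the step or one alone would give it, and how other groups on the same carbonyl carbon, such as a chlorophenyl, a methoxyphenyl or a pyridyl ring, would compare with phenyl. They also leave open whether the same change would move the number in the same direction on compound 2, which gives 585 nM with phenyl in this place.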